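This account rests on a few compounds, and the source may have more. Where it says the series, first, only, none or still open, it means among the compounds named here.

Compounds measured so far in an assay for binding affinity to leukotriene B4 receptor 1 (Homo sapiens); a higher number here means a weaker inhibitor, a lower number a stronger inhibitor:
compound 1 `O=C(O)CCCCCOc1cc(-c2ccccc2)cc(-c2ccc(F)cc2)n1`: 30 nM
compound 2 `CC(CCCCOc1cc(-c2ccccc2)cc(-c2ccccc2F)n1)C(=O)O`: 18 nM
compound 3 `CC(CCCCOc1cc(-c2ccccc2)cc(-c2ccccc2)n1)C(=O)O`: 30 nM

In this assay compound 3 sits level with compound 1 at the digits shown, and the one single-point step, a 1.7-fold higher number from compound 2 to compound 3 (0.22 log units; within the scatter), lies within the scatter, so the three measured values do not separate from one another. Compound 4 `NC(=O)CCCCCOc1cc(-c2ccccc2)cc(-c2ccccc2)n1` differs from compound 3 by carbamoylmethyl in place of 1-carboxyethyl on a saturated chain carbon, four bonds along the chain from an oxygen on an aromatic ring. Among the measured compounds shown here, no measured step bears on this change: the step from compound 2 to compound 3 concerns only a fluoro on an aromatic carbon, far from the chain end. The estimate for compound 4 therefore rests on compound 3 alone and carries a wide range. Compound 4 is expected to give 150 nM, between 25 nM and 900 nM, an expected 5.0-fold higher number from compound 3 to compound 4 (0.70 log units; beyond the scatter).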

Compound 4, half-maximal inhibitory concentration: 150 nM
Compound 4: middle estimate and measured number agree at the digits printed; the measured number falls inside the stated range.
By their numbers in this assay, from the lowest: compounds 2, 1 and 3 (each within the scatter of the next); then compound 4.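

In this assay the change on the saturated chain gives a 5.0-fold higher number from compound 3 to compound 4 (0.70 log units; beyond the scatter) and is the first step shown that lies beyond the scatter, so this position matters for the read-out in a way the fluoro step did not show. A carboxylic acid and a methyl branch leave together here as an amide enters, and the pair cannot show which of these changes carries the step. Nothing available explains the step.

Still open, going by these compounds, is how an unbranched carboxylic acid would compare on the same core. Also open, on these data alone, is how an amine or a methyl ester would behave at this position.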